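The source may hold more compounds than are shown below. What is called first, only, known or untested is meant among the compounds shown, and "the series" means these compounds.

Working notes on the series: in a functional assay on CCRF-CEM cells (Homo sapiens) for cytotoxicity (a lower number here means that less compound is tolerated, a higher number that more compound is tolerated), compound 1 `Cc1cc(C)c2c(c1)COP(=O)(OCC1CCC(n3cnc4c(N)ncnc43)O1)O2` gives 10000 nM, compound 2 `Nc1ncnc2c1ncn2[C@H]1C=C[C@@H](COP2(=O)OCc3ccccc3O2)O1` gives 86000 nM, and compound 3 `Cc1cc(C)c2c(c1)COP(=O)(OC[C@@H]1C=C[C@H](n3cnc4c(N)ncnc43)O1)O2` gives 25000 nM. Compound 3 therefore holds the middle place of the three, with both gaps beyond the scatter. Compound 4 `Cc1cccc2c1OP(=O)(OC[C@@H]1C=C[C@H](n3cnc4c(N)ncnc43)O1)OC2` has hydrogen in place of methyl on an aromatic carbon. Going by the values given here, no measured step isolates this change, so its size remains uncertain. A modest rise in this assay is expected, and a result within the scatter would be unsurprising. Among the compounds with values here, the highest number so far belongs to compound 2, at 86000 nM. The estimated step is a 1.6-fold higher number from compound 3 to compound 4 (0.20 log units; within the scatter). For compound 4 the estimate is 40000 nM, with an expected range of 18000 nM to 85000 nM.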

Compound 4, half-maximal cytotoxic concentration: 49000 nM
Compound 4: middle estimate off by 1.2-fold (0.09 log units), on the low side; the range from low to high includes it.
By their numbers in this assay, from the lowest: compound 1; then compounds 3, 4 and 2 (each within the scatter of the next, the first and the last beyond it).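

In this assay, the methyl on this aromatic carbon can now be read directly: hydrogen in its place gives a 2.0-fold higher number from compound 3 to compound 4 (0.29 log units; within the scatter). The second single change, methyl in place of hydrogen on an aromatic carbon, gives a 1.8-fold lower number from compound 2 to compound 4 (0.24 log units; within the scatter), so neither step separates its two compounds in this assay. Nothing at hand explains either step. On these data alone, whether a larger group at this aromatic carbon, such as a methoxy, a chlorine or an ethyl, would move the number beyond the scatter remains open.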